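This account rests on a few compounds, and the source may have more. Where it says the series, first, only, none or still open, it means among the compounds named here.

Measured so far in a functional assay on A549 cells (Homo sapiens) for antiproliferative activity, read by MTT assay, with a stated time of 72 h; on this read-out higher numbers stand for weaker inhibition and lower numbers for stronger inhibition:
- compound 1 `O=C1NC(=O)/C(=C/C2=Cc3ccccc3OC2)S1` gives 192000 nM
- compound 2 `CN1C(=O)S/C(=C\C2=Cc3ccccc3OC2)C1=O` gives only a limit, > 100000 nM
- compound 3 `CCN1C(=O)S/C(=C\C2=Cc3ccccc3OC2)C1=O` gives only a limit, > 200000 nM

Going by the values given here, compound 1 therefore holds the only number in this assay; the other two entries are limits, namely the limit of > 100000 nM in this assay, at which 1 of the 3 values shown sits, and (the limit of > 200000 nM in this assay, at which 1 of the 3 values shown sits). Compound 4 `O=C1NC(=O)/C(=C/C2=Cc3cc(Br)ccc3OC2)S1` differs from compound 1 by bromo in place of hydrogen on an aromatic carbon. All three measured steps concern the ring nitrogen and not the aromatic ring: a step that the limit leaves unreadable from compound 1 to compound 2, an at least 1.0-fold higher number from compound 1 to compound 3 (0.01 log units; that floor lies within the scatter) and a step that the two limits leave unreadable from compound 2 to compound 3, and none of them is shown to reach beyond the scatter. Among the compounds with values here, no measured step thus speaks to the bromo change, so for compound 4 no step beyond the scatter is expected in this assay, though with wide uncertainty. Compound 4 is estimated at 150000 nM, with a range from 50000 nM to 400000 nM. This estimate means an expected 1.3-fold lower number from compound 1 to compound 4 (0.11 log units; within the scatter).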

Compound 4, half-maximal inhibitory concentration: 79500 nM
The estimate for compound 4 lay 1.9-fold (0.28 log units) above the measured number, and the stated range covers the measured number.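

Bromo in place of hydrogen on an aromatic carbon brings a 2.4-fold lower number from compound 1 to compound 4 (0.38 log units; beyond the scatter) in this assay and so gives a modest gain in inhibition. Among the steps shown, this is the only one beyond the scatter, and it shows that a change on the aromatic ring of the shared core can move the number. Nothing measured here explains this step.

Going by these compounds, whether a fluoro, a methoxy or an amine on the same carbon would give a larger or smaller step remains open. So does whether bromo would have a similar effect with an ethyl on the ring nitrogen.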